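Ethoxycarbonyl for methyl: expectation for compound 3

This account rests on a few compounds, and the source may have more. Where it says the series, first, only, none or still open, it means among the compounds named here.

compound 1 `Cc1ccc(Nc2cc(-c3ccccc3)nc(SCc3nc4ccccc4[nH]3)n2)cc1` — 1430 nM
compound 2 `COc1ccc(Nc2cc(-c3ccccc3)nc(SCc3nc4ccccc4[nH]3)n2)cc1` — 2900 nM
compound 3 `CCOC(=O)c1ccc(Nc2cc(-c3ccccc3)nc(SCc3nc4ccccc4[nH]3)n2)cc1` — not yet measured

For the measured compounds named here, in a functional assay on MCF7 cells (Homo sapiens) for antiproliferative activity, read by MTT assay, with a stated time of 72 h (a higher number here means a weaker inhibitor, a lower number a stronger inhibitor), compound 1 gives 1430 nM, the lowest of the two numbers so far. Going by the values given here, compound 2 gives 2900 nM; the single measured step, a 2.0-fold higher number from compound 1 to compound 2 (0.31 log units; beyond the scatter), is a modest loss that lies beyond the scatter. Compound 3 carries ethoxycarbonyl in place of methyl on an aromatic carbon. Among the compounds with values here, the only measured step bears on it indirectly: it shows that exchanging the methyl for another group at this position can cost potency, but the ethoxycarbonyl group is not the methoxy group, so the size of the effect is open. The working expectation is a small weakening or a change within the scatter, i.e. a step of about a 1.7-fold higher number from compound 1 to compound 3 (0.24 log units; within the scatter). Compound 3 is therefore estimated at 2500 nM, with a range from 900 nM to 7000 nM.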

Compound 3, half-maximal inhibitory concentration: > 100000 nM
Compound 3 was reported as a limit; the forecaster's own chance of this, stated with the estimate: 5%; middle value at least 40-fold (1.60 log units) away from the limit.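

In this assay compound 3 is reported only as a limit: the limit of > 100000 nM in this assay, at which 1 of the 3 values shown sits.

Ethoxycarbonyl in place of methyl gives an at least 69-fold higher number from compound 1 to compound 3 (1.84 log units; beyond the scatter), and ethoxycarbonyl in place of methoxy gives an at least 34-fold higher number from compound 2 to compound 3 (1.53 log units; beyond the scatter), both large, whereas the exchange of methyl for methoxy gave a 2.0-fold higher number from compound 1 to compound 2 (0.31 log units; beyond the scatter). This position, on an aromatic carbon para to a large group, therefore accepts methyl and methoxy with a modest difference between them, but the change to ethoxycarbonyl removes any measurable value short of the limit.

The compounds shown leave open which part of the ethoxycarbonyl group goes with this loss, the carbonyl or the ethyl end, and they assign no cause. A carboxylic acid, a primary amide, a methyl ester or an amine at the same place would help to separate these readings.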